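Cyclohexyl on the urea nitrogen of compound 3

The compounds below may be only part of what the source reports. "The series", "measured", "known", "first", "only" and "open" are said of these compounds alone.

Measured compounds:
Compound 1 `CCN(C)C(=O)N1CCN(C(=S)SCc2cn(Cc3ccccc3F)nn2)CC1` in a functional assay on SMMC-7721 cells (Homo sapiens) for cytotoxicity, read by MTT assay, with a stated time of 72 h (on this read-out lower numbers stand for stronger inhibition and higher numbers for weaker inhibition), gives 19700 nM.
Compound 2 `O=C(NCc1ccccc1)N1CCN(C(=S)SCc2cn(Cc3ccccc3F)nn2)CC1` in this assay gives only a limit of the assay, > 128000 nM.
Compound 3 `NC(=O)N1CCN(C(=S)SCc2cn(Cc3ccc(F)cc3)nn2)CC1` in this assay gives only a limit of the assay, > 128000 nM.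

Compound 3 therefore stands at the limit, and no number is known for it. One further value sits at that limit as well, namely (the limit of > 128000 nM in this assay, at which 2 of the 3 values shown sit). Compound 4 `O=C(NC1CCCCC1)N1CCN(C(=S)SCc2cn(Cc3ccc(F)cc3)nn2)CC1` differs from compound 3 in one place: cyclohexyl in place of hydrogen on an amide-type nitrogen. Among the compounds with values here, the one measured step that touches the same nitrogen, an at least 6.4-fold higher number from compound 1 to compound 2 (0.81 log units; beyond the scatter), puts a larger group there and ends at the limit, so a larger group on this nitrogen has so far gone with a weaker number. For compound 4 the step of an at least 1.4-fold lower number from compound 3 to compound 4 (0.15 log units; that floor lies within the scatter) is therefore expected to stay near the limit of this assay, with no number or a weak one. The estimate for compound 4 in this assay is 90000 nM, within 20000 nM to 300000 nM.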

Compound 4, half-maximal inhibitory concentration: > 128000 nM
Compound 4 ended at the assay's limit; the forecaster's own chance of this, stated with the estimate: 60%; at least 1.4-fold (0.15 log units) between middle value and limit.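

Compound 4, like compound 3, gives only a limit in this assay, so the step between them cannot be read: the limit of > 128000 nM in this assay, at which 3 of the 4 values shown sit.

The compounds shown leave open whether cyclohexyl in place of hydrogen on this amide-type nitrogen changes the activity at all.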